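A Hydroxy Group Enters the Chain of Compound 1

The source may hold more compounds than are shown below. What is called first, only, known or untested is meant among the compounds shown, and "the series" means these compounds.

Of the compounds shown here, three built on a shared core have been measured in an assay on cells for inhibition of Indoleamine 2,3-dioxygenase 1 (Homo sapiens), with a stated time of 7 h, tested at 200 uM; a higher number here means more inhibition at the concentration tested (going by the name of the read-out), a lower number less inhibition. Compound 1 `c1ccc(CCc2ccccc2-c2c[nH]nn2)cc1` gives 58% in this assay . Compound 2 `Clc1ccc(CCc2ccccc2)c(-c2c[nH]nn2)c1`, which carries a chloro in place of hydrogen on an aromatic carbon, gives 70% in this assay . Compound 3 `c1ccc(-c2c[nH]nn2)c(CCC2CCCC2)c1`, with a cyclopentyl in place of phenyl on a saturated chain carbon, gives 74% in this assay . Compound 1 therefore stands lowest of the three: the step of a number 12 percentage points higher from compound 1 to compound 2 (beyond the scatter) and the step of a number 16 percentage points higher from compound 1 to compound 3 (beyond the scatter) both lie beyond the scatter, and both are modest in size.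

Compound 4 `OC(Cc1ccccc1-c1c[nH]nn1)c1ccccc1` differs from compound 1 in one place: hydroxy in place of hydrogen on a saturated chain carbon bound to an aromatic carbon and a saturated chain carbon. Neither measured step concerns this position or a group of this kind; the chloro step and the cyclopentyl step change other parts of the molecule, so they offer no direct guide. With no comparable change among the measured compounds, the expectation is for a step of a number 3 percentage points lower from compound 1 to compound 4 (within the scatter), that is, none beyond the scatter in this assay . Compound 4 is accordingly estimated at 55% in this assay , within a range from 35% to 75%.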

Compound 4, a percentage reported as inhibition, at one concentration (the size of the read-out at that concentration, not a potency): 28%
Beside the measured number, compound 4's estimate is 27 percentage points above it; the measured number lies below the stated range.
By their numbers in this assay, from the lowest: compound 4; then compound 1; then compounds 2 and 3 (each within the scatter of the next).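

The saturated chain carbon bound to an aromatic carbon and a saturated chain carbon turns out to be a place where a single added atom alters the result: in this assay, hydroxy in place of hydrogen there gives a number 30 percentage points lower from compound 1 to compound 4 (beyond the scatter). The earlier steps pointed only upward, with the chloro change giving a number 12 percentage points higher from compound 1 to compound 2 (beyond the scatter) and the cyclopentyl change giving a number 16 percentage points higher from compound 1 to compound 3 (beyond the scatter), so this is the first change among the compounds shown that lowers the number beyond the scatter, and it shows that the core of compound 1 can lose inhibition as well as gain it through a change in its chain. No supporting data are available to explain why this hydroxy lowers the number.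

The compounds shown leave open whether the drop belongs to hydroxy itself or would also follow from another group on the same carbon, such as methoxy, fluoro or an amine. They also leave open whether hydroxy at this place would lower the number to a similar extent in a compound that also carries the chloro of compound 2 or the cyclopentyl of compound 3.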